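Butylcarbamoyl for fluoro on an inactive compound

The source may hold more compounds than are shown below. What is called first, only, known or untested is meant among the compounds shown, and "the series" means these compounds.

Values so far in a functional assay on MCF7 cells (Homo sapiens) for antiproliferative activity, read by CCK-8 assay, with a stated time of 72 h (a lower number here means a stronger inhibitor of growth, a higher number a weaker inhibitor of growth), for growth inhibition
- compound 1 `CCCNS(=O)(=O)c1ccc(Nc2ncc3c(n2)N(c2ccn(C)n2)C(CC)C(=O)N3C)cc1` gives 3000 nM
- compound 2 `CC[C@@H]1C(=O)N(C)c2cnc(-n3ccc4cc(F)ccc43)nc2N1C1CCCC1` gives "not active" (no number reported)

Compound 2 has no number, only the report "not active" (no number reported) as its result. Compound 3 `CCCCNC(=O)c1ccc2c(ccn2-c2ncc3c(n2)N(C2CCCC2)[C@H](CC)C(=O)N3C)c1` is still to be measured. The change butylcarbamoyl in place of fluoro on an aromatic carbon puts butylcarbamoyl in place of fluoro on an aromatic carbon. Among the measured compounds shown here, no measured step covers this change, so its size in this assay cannot be read from the data. A modest move toward stronger inhibition is expected, on the scale set by compound 1 at 3000 nM as the only numeric anchor. For compound 3 the estimate is 5000 nM and it is expected to fall between 1000 nM and 25000 nM.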

Compound 3, concentration for 50% growth inhibition: 634 nM
The estimate for compound 3 lay 7.9-fold (0.90 log units) above the measured number, and the stated range ends above it.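

No step can be read in this assay, since compound 2 carries only the report "not active" and compound 3 has a number. The compounds shown leave open how much butylcarbamoyl in place of fluoro contributes. No data shown bear on a cause for this result.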